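Side-chain swap carried from one core to the other

The source may report more compounds than this note shows. Statements on the series, on what has been measured and on what is new or still open speak of the compounds shown alone.

Measured so far in a functional assay for inhibition, read by spectrophotometry, with a stated time of 20 min, tested at 1 mg/mL; a higher number here means a stronger effect of the compound at the concentration tested, a lower number a weaker effect:
compound 1 `CC(=O)c1ccc(NC(=O)C(CC(C)C)N(C(=O)c2ccccc2)S(=O)(=O)c2ccc(C)cc2)cc1`: 54%
compound 2 `CCC(C)C(C(=O)Nc1ccc(C(C)=O)cc1)N(C(=O)c1ccccc1)S(=O)(=O)c1ccc(C)cc1`: 18.6%
compound 3 `CC(=O)c1ccc(NC(=O)C(CC(C)C)N(C(=O)c2ccccc2)S(=O)(=O)c2ccc([N+](=O)[O-])cc2)cc1`: 45%

The change from compound 1 to compound 2 is sec-butyl in place of isobutyl on a saturated chain carbon bound to an amide-type nitrogen and a carbonyl carbon; the step it made was a number 35.4 percentage points lower from compound 1 to compound 2 (beyond the scatter). The core of compound 3 differs from the core of compound 1 by nitro in place of methyl on an aromatic carbon, a step of a number 9 percentage points lower from compound 1 to compound 3 (within the scatter), so the two cores sit close together in this assay.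

Compound 4 `CCC(C)C(C(=O)Nc1ccc(C(C)=O)cc1)N(C(=O)c1ccccc1)S(=O)(=O)c1ccc([N+](=O)[O-])cc1` applies the same change to compound 3: sec-butyl in place of isobutyl on a saturated chain carbon bound to an amide-type nitrogen and a carbonyl carbon. The place is the same word for word as in the first pair, so this is the same change on a near-equivalent core.

Going by the values given here, the step from compound 3 to compound 4 is expected to be a number 33 percentage points lower from compound 3 to compound 4 (beyond the scatter), a loss of similar size to the earlier one, because the only prior example of this change gave a number 35.4 percentage points lower from compound 1 to compound 2 (beyond the scatter) and the core step was a number 9 percentage points lower from compound 1 to compound 3 (within the scatter). Compound 4 is therefore estimated at 12% in this assay, expected between 0% and 28%.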

Compound 4, a percentage reported as inhibition, at one concentration (the size of the read-out at that concentration, not a potency): 28.6%
Estimate against measurement, compound 4: 16.6 percentage points below; the measured number lies above the stated range.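

Sec-butyl in place of isobutyl again lowers the number in this assay, with a number 16.4 percentage points lower from compound 3 to compound 4 (beyond the scatter), so the direction carries over to the nitro core but the size does not: the same change on two cores in this assay, a number 35.4 percentage points lower (beyond the scatter) from compound 1 to compound 2 and a number 16.4 percentage points lower (beyond the scatter) from compound 3 to compound 4, 19 percentage points apart, beyond the scatter of two such steps. Nitro in place of methyl, read on the sec-butyl compounds, gives a number 10 percentage points higher from compound 2 to compound 4 (within the scatter), and this does not match its counterpart on the isobutyl compounds: the same change on two cores in this assay, a number 9 percentage points lower (within the scatter) from compound 1 to compound 3 and a number 10 percentage points higher (within the scatter) from compound 2 to compound 4, 19 percentage points apart, beyond the scatter of two such steps. Two pairs show that the side-chain and aromatic changes do not add up independently here, but they do not show what sets the size of either step or how it would behave on a third core.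

Open, as far as these compounds go, is whether a methoxy group or a chlorine in place of nitro or methyl would give the same side-chain step. Also open, from the compounds shown here alone, is how a longer chain or a benzyl group would compare with isobutyl on these cores.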